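This account rests on a few compounds, and the source may have more. Where it says the series, first, only, none or still open, it means among the compounds named here.

For the measured compounds named here, in a functional assay on L1210 cells (Mus musculus) for inhibition (a higher number here means a weaker inhibitor, a lower number a stronger inhibitor), compound 1 `Nc1ncnc2c1ncn2C/C=C\CCl` gives 22000 nM, the only true number so far. Compound 3 `Nc1ncnc2c1ncn2/C=C/CCO` keeps the core of compound 1 and alters the chain on an aromatic nitrogen of the five-membered ring, with 4-hydroxybut-1-en-1-yl in place of 4-chlorobut-2-en-1-yl on an aromatic nitrogen. Going by the values given here, no measured pair shows this change, so any forecast is uncertain. Compound 2 `Nc1ccn(C/C=C\CO)c(=O)n1` also carries a hydroxy-ended chain, and its > 1000000 nM is a limit of the assay, so a weaker inhibitor is expected. The expected change is a 9.1-fold higher number from compound 1 to compound 3 (0.96 log units; beyond the scatter), a loss well beyond the scatter. For compound 3 the estimated value is 200000 nM, with an expected range of 50000 nM to 1000000 nM.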

Compound 3, half-maximal inhibitory concentration: 100000 nM
Estimate against measurement, compound 3: 2.0-fold (0.30 log units) above, within the range that was stated.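

In this assay, moving to the hydroxy-ended chain on the aromatic nitrogen gives a 4.5-fold higher number from compound 1 to compound 3 (0.66 log units; beyond the scatter), so inhibition weakens but remains measurable. On this shared core, a chain ending in hydroxy therefore still yields a true number. Compound 2 gives only a limit of the assay, not a number: the limit of > 1000000 nM in this assay, at which 1 of the 3 values shown sits.

Since 4-hydroxybut-1-en-1-yl differs from 4-chlorobut-2-en-1-yl in both its end group and its double-bond position, the compounds shown cannot separate these two changes. They also leave open how an amine or a carboxylic acid at the chain end, or a longer chain, would behave.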